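The compounds below may be only part of what the source reports. "The series", "measured", "known", "first", "only" and "open" are said of these compounds alone.

Of the compounds shown here, three of one shared core have been measured in an ADME assay on HEK293 cells (Homo sapiens) for antiproliferative activity, read by MTT assay, with a stated time of 24 h; a lower number here means a stronger inhibitor, a higher number a weaker inhibitor. Compound 1 `COc1ccc(-c2cc(C(=O)/C=C/c3ccccc3)nc3cc(-c4ccccc4)nn23)cc1OC` gives 64100 nM. Compound 2 `COc1cc(-c2cc(C(=O)/C=C/c3ccccc3)nc3cc(-c4ccccc4)nn23)cc(OC)c1OC` gives 44800 nM, and the step of a 1.4-fold lower number from compound 1 to compound 2 (0.16 log units; within the scatter) adds a methoxy on an aromatic carbon. Compound 3 `COc1cc(-c2cc(/C=C/C(=O)c3ccc(Cl)cc3)nc3cc(-c4ccccc4)nn23)cc(OC)c1OC` reaches only the limit of this assay, at >= 100000 nM, which is a limit and not a number; the step of an at least 2.2-fold higher number from compound 2 to compound 3 (0.34 log units; beyond the scatter) swaps the order of the carbonyl and the double bond in the chain. Among the two plain numbers, compound 2 stands lowest, with compound 1 nearest and within the scatter of it, so no order between the two can be claimed.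

Compound 4 `COc1cc(/C=C/C(=O)c2cc(-c3cc(OC)c(OC)c(OC)c3)n3nc(-c4ccccc4)cc3n2)cc(OC)c1OC` is not yet measured. It differs from compound 2 in one place: 3,4,5-trimethoxyphenyl in place of phenyl on a double-bonded chain carbon bound to a double-bonded chain carbon. Going by the values given here, the only measured step of a similar kind, adding a methoxy to an aromatic ring in a 1.4-fold lower number from compound 1 to compound 2 (0.16 log units; within the scatter), stayed within the scatter, while the step that moved the carbonyl, an at least 2.2-fold higher number from compound 2 to compound 3 (0.34 log units; beyond the scatter), does not touch the part changed here. The expectation for compound 4 in this assay is therefore a step of a 1.1-fold higher number from compound 2 to compound 4 (0.05 log units; within the scatter) from compound 2, that is, no clear change beyond the scatter.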

Compound 4, half-maximal inhibitory concentration: 41000 nM
Beside the measured number, compound 4's estimate is 1.2-fold (0.09 log units) above it, and the stated range covers the measured number.
By their numbers in this assay, from the lowest: compounds 4, 2 and 1 (each within the scatter of the next). At a limit, above all of these: compound 3.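

In this assay, the first change shown at this place, 3,4,5-trimethoxyphenyl in place of phenyl on a double-bonded chain carbon bound to a double-bonded chain carbon, gives a 1.1-fold lower number from compound 2 to compound 4 (0.04 log units; within the scatter). Going by these compounds alone, the earlier steps changed the methoxy count on the other aromatic ring and the order of the carbonyl and the double bond, so this is the first reading of the far end of the chain: the entering group has 12 heavy atoms where phenyl has 6, and 3 hydrogen-bond acceptors where phenyl has 0, yet the number does not move beyond the scatter. No measurement shown here gives a reason for this outcome.

From the compounds shown here alone, whether a group of another kind on this chain carbon, such as an amine or a carboxylic acid, would move the number beyond the scatter remains open. Also open, going by these compounds, is whether a longer chain between the carbonyl and this aromatic ring would leave the number as unchanged as the 3,4,5-trimethoxyphenyl group did.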